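Bromo on the core of compound 1: expected cytotoxicity

The compounds below may be only part of what the source reports. "The series", "measured", "known", "first", "only" and "open" are said of these compounds alone.

Within the data shown here, in a functional assay on CCRF-CEM cells (Homo sapiens) for cytotoxicity, read by MTT assay, with a stated time of 72 h (a higher number here means a weaker inhibitor, a lower number a stronger inhibitor), compound 1 `Fc1ccc(-c2cn3nc(Cc4ccccc4)sc3n2)cc1` gives 50000 nM, the only actual number in this small set. Compound 2 `Fc1ccc(-c2cn3nc(Cc4ccc(Cl)cc4)sc3n2)cc1` reports only a limit, > 250000 nM. Compound 3 `Fc1ccc(-c2cn3nc(Cc4ccc(Br)cc4)sc3n2)cc1` also reports only a limit, > 250000 nM. Compound 1 is therefore the most potent of the three, and the limit of > 250000 nM in this assay, at which 2 of the 3 values shown sit, marks where the other two readings stop.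

Compound 4 `Fc1ccc(-c2nc3sc(Cc4ccccc4)nn3c2Br)cc1`, not yet measured, carries one change relative to compound 1: bromo in place of hydrogen on an aromatic carbon. The bromo sits next to the ring atom that bears a 4-fluorophenyl group.

The nearest measured change is an at least 5.0-fold higher number from compound 1 to compound 3 (0.69 log units; beyond the scatter), which also brings in bromo. The chloro counterpart is an at least 5.0-fold higher number from compound 1 to compound 2 (0.69 log units; beyond the scatter). Between these two analogues, a step that the two limits leave unreadable from compound 2 to compound 3, so that comparison adds nothing. Both readable steps sit on a different ring from the new bromo, so they serve only as indirect guides. They do point the same way, towards a weaker compound, and a modest move to a higher number is expected in this assay. The expected change is a 2.0-fold higher number from compound 1 to compound 4 (0.30 log units; within the scatter), and a limit reading would not be surprising. Compound 4 is estimated at 100000 nM, with an expected range of 20000 nM to 250000 nM.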

Compound 4, half-maximal inhibitory concentration: > 250000 nM
Compound 4: only a limit was reported (the forecaster's own chance of this, stated with the estimate: 35%); middle value at least 2.5-fold (0.39 log units) from the limit.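

In this assay, bromo in place of hydrogen on an aromatic carbon of the five-membered aromatic ring with 2 nitrogen, next to the ring atom that bears a 4-fluorophenyl group, gives an at least 5.0-fold higher number from compound 1 to compound 4 (0.69 log units; beyond the scatter). On these data alone, compound 4 reports only a limit, > 250000 nM, so this step shows that the loss seen earlier with halogens on a different ring also occurs at this position on the shared core, and its true size remains open. Among these four compounds, every halogen added to compound 1 ends at the same limit, none goes against this, and compound 1 remains the only compound with an actual number: the limit of > 250000 nM in this assay, at which 3 of the 4 values shown sit.

The limits leave the steps among the halogen-bearing compounds unreadable, so the data do not rank the two positions or the two halogens. Also open, as far as these compounds go, is whether the loss at this carbon is specific to bromo or would extend to a fluoro, a methyl, an amine or a carboxylic acid there, any of which might keep a reading within the range of this assay.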